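Dichloro versus monochloro purines: series notes

This account rests on a few compounds, and the source may have more. Where it says the series, first, only, none or still open, it means among the compounds named here.

Measured compounds:
compound 1, `ClCc1ccc(Cn2cnc3nc(Cl)nc(Cl)c32)cc1`, 2810 nM
compound 2, `ClCc1ccccc1Cn1cnc2ncnc(Cl)c21`, 22900 nM
compound 3, `ClCc1ccccc1Cn1cnc2nc(Cl)nc(Cl)c21`, 5240 nM

All three were run in a functional assay on IGROV-1 cells (Homo sapiens) for cytotoxicity, read by sulforhodamine B assay, with a stated time of 48 h; on this read-out lower numbers stand for stronger inhibition of growth and higher numbers for weaker inhibition of growth. Compound 1 gives the lowest number of the three in this assay; its gap to compound 3 is within the scatter, so the two are not ranked against each other. Compound 2 stands clearly apart from both. For the measured compounds named here, the single change between compound 3 and compound 2 is hydrogen in place of chloro on an aromatic carbon, and it carries a 4.4-fold higher number from compound 3 to compound 2 (0.64 log units; beyond the scatter). The cores of compound 1 and compound 3 are built from the same atoms joined differently; that difference is not broken down here.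

Compound 4, `ClCc1ccc(Cn2cnc3ncnc(Cl)c32)cc1`, is not yet measured in this assay. It stands to compound 1 as compound 2 stands to compound 3: the change is hydrogen in place of chloro on an aromatic carbon, the same change at the same place. Going by the values given here, the expectation for compound 4 therefore rests on the one measured instance, a 4.4-fold higher number from compound 3 to compound 2 (0.64 log units; beyond the scatter), carried over to compound 1 with 2810 nM as the starting point. The expected step is a 4.3-fold higher number from compound 1 to compound 4 (0.63 log units; beyond the scatter), similar in size to the earlier one. Compound 4 is estimated at 12000 nM, with a likely range from 5000 nM to 30000 nM.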

Compound 4, concentration for total growth inhibition: 30900 nM
Compound 4: the middle estimate sits 2.6-fold (0.41 log units) below what was measured, outside the stated range (above it).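

In this assay hydrogen in place of chloro on an aromatic carbon between two ring nitrogen atoms gives an 11-fold higher number from compound 1 to compound 4 (1.04 log units; beyond the scatter) and this step is large. Set beside the earlier step, it does not separate from it in size: the same change on two cores in this assay, a 4.4-fold higher number (0.64 log units; beyond the scatter) from compound 3 to compound 2 and an 11-fold higher number (1.04 log units; beyond the scatter) from compound 1 to compound 4, 2.5-fold (0.40 log units) apart, within the scatter of two such steps. The change therefore carries from one core to the other in direction, and the two sizes cannot be told apart, but two pairs in a single assay do not show that the step would hold on any further core, nor do they give its size more closely than this.

The compounds shown leave open what an amine or a methoxy group would give in place of the chloro group at that carbon. From the compounds shown here alone, all four compounds also carry the chloromethyl group, so the effect of a hydroxymethyl or plain methyl group in its place, and whether the step above survives such a swap, stays open.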